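Thienylsulfonamide isoindolinone series: cyclopropyl for cyclobutyl on piperazine

A few compounds are considered here, and "the series" means these few. Any claim that something is new, unique, unknown or untested is made for them only; others in the source may bear on it.

Three compounds have numbers in a functional assay on CHO-K1 cells for antagonist activity at Urotensin-2 receptor (Rattus norvegicus), read by FLIPR and calcium flux, with a stated time of 1 h; on this read-out higher numbers stand for weaker inhibition and lower numbers for stronger inhibition. Compound 1 `COc1cc(Br)c(S(=O)(=O)Nc2ccc(C(F)(F)F)c(O[C@@H]3CCN(C)C3)c2)cc1OC` gives 34 nM, compound 2 `CCN1CCN(c2cccc3c2C(=O)N([C@H](CCCNS(=O)(=O)c2cn(C)c(C)n2)c2ccc(OC)c(OC)c2)C3=O)CC1` gives 140 nM, and compound 3 `COc1ccc([C@@H](CCCN(C)S(=O)(=O)c2cccs2)N2Cc3c(cccc3N3CCN(C4CCC4)CC3)C2=O)cc1OC` gives 4 nM. Compound 3 therefore holds the lowest number of the three, with compound 1 nearest and compound 2 furthest; both gaps lie beyond the scatter, so compound 3 is the strongest inhibitor among the measured set.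

Compound 4 `COc1ccc([C@@H](CCCN(C)S(=O)(=O)c2cccs2)N2Cc3c(cccc3N3CCN(C4CC4)CC3)C2=O)cc1OC` has not yet been measured in this assay. It differs from compound 3 in one place: cyclopropyl in place of cyclobutyl on an amine nitrogen in a ring. Among the compounds with values here, no measured pair in the set carries this change, so there is no measured step to lean on. The change is one carbon atom of a small ring on the amine nitrogen of the piperazine; no step beyond the scatter is expected from it. Because compound 3 gives 4 nM in this assay and the difference is small, compound 4 is expected near 6 nM, with a range of 2 nM to 18 nM. The expected step of a 1.5-fold higher number from compound 3 to compound 4 (0.18 log units; within the scatter) is estimated to stay within the scatter.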

Compound 4, half-maximal inhibitory concentration: 13 nM
Estimate against measurement, compound 4: 2.2-fold (0.34 log units) below; measured number inside the range.
By their numbers in this assay, from the lowest: compound 3; then compound 4; then compound 1; then compound 2.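

In this assay, within the data shown here, the group on the amine nitrogen of the piperazine is not interchangeable between these two small rings: cyclopropyl in place of cyclobutyl gives a 3.3-fold higher number from compound 3 to compound 4 (0.51 log units; beyond the scatter) and so provides the first measured step at this position. Within this pair, 4-cyclobutylpiperazin-1-yl holds the lower number and is the stronger inhibitor, so even this small change on the nitrogen registers on this read-out. No supporting measurement is available to explain the step.

On these data alone, two ring sizes at this nitrogen do not establish a trend, so it remains open whether cyclopentyl or an open chain such as isopropyl would give a number nearer that of compound 3. As far as these compounds go, it also remains open whether the step would hold with a group other than the thienylsulfonamide on the shared core.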